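Moving the chlorine one carbon further from the carbonyl

The compounds below may be only part of what the source reports. "The series", "measured", "known", "first", "only" and "open" are said of these compounds alone.

Measured so far:
compound 1, `CC(C)(C)c1ccc(NC(=O)CCl)cc1`: 5400 nM
compound 2, `CC(C)(C)c1ccc(NC(=O)CCCl)cc1`: 74000 nM
compound 3, `CC(C)(C)c1ccc(CNC(=O)CCCl)cc1`: > 100000 nM

All values come from a functional assay on M21 cells (Homo sapiens) for antiproliferative activity, with a stated time of 48 h; on this read-out lower numbers stand for stronger inhibition and higher numbers for weaker inhibition. Compound 1 and compound 2 differ in one place, (chloromethyl in place of chloro on a saturated chain carbon bound to a carbonyl carbon), and this change gives a 14-fold higher number from compound 1 to compound 2 (1.14 log units; beyond the scatter). For compound 3 this assay gives only a limit, > 100000 nM. How the core of compound 3 differs from the core of compound 1 is not broken down here.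

The unmeasured compound 4, `CC(C)(C)c1ccc(CNC(=O)CCCCl)cc1`, carries the same kind of change relative to compound 3, (chloromethyl in place of chloro on a saturated chain carbon, two bonds along the chain from a carbonyl carbon); the difference is that the saturated chain carbon now sits two bonds along the chain from the carbonyl carbon rather than bound to it. Compound 4 is expected to sit at or beyond the limit (the limit of > 100000 nM in this assay, at which 1 of the 3 values shown sits), since compound 3 already gives > 100000 nM and the step from compound 1 to compound 2 went toward weaker inhibition. The expected step is therefore a step that the limit leaves unreadable from compound 3 to compound 4, and the estimate for compound 4 is 300000 nM, between 100000 nM and 1500000 nM.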

Compound 4, half-maximal inhibitory concentration: 69000 nM
Estimate against measurement, compound 4: 4.3-fold (0.64 log units) above, outside the stated range (below it).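

In this assay compound 3 gives > 100000 nM and this is a limit of the assay, not a number. Read against that limit, adding one carbon to the chlorine-bearing chain gives an at least 1.4-fold lower number from compound 3 to compound 4 (0.16 log units; that floor lies within the scatter) and the same change does not behave alike on the two cores: the same change on two cores in this assay, a 14-fold higher number (1.14 log units; beyond the scatter) from compound 1 to compound 2 and an at least 1.4-fold lower number (0.16 log units; that floor lies within the scatter) from compound 3 to compound 4, at least 19-fold (1.29 log units) apart, beyond the scatter of two such steps

So this change does not carry a fixed size from one core to the other, yet the step on the core of compound 3 is known only as a floor, and two pairs give no general rule and no reason for the gap.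

Still open, as far as these compounds go, is how the 3-chloropropyl chain would behave on the core of compound 1, which would add a further point to that series. Also open, from the compounds shown here alone, is whether a longer chain, or an amine or a fluorine atom in place of the chlorine, would change the result on either core.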